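The source may report more compounds than this note shows. Statements on the series, on what has been measured and on what is new or still open speak of the compounds shown alone.

Working notes on the chain series. Compound 1 `CCCCN1NN=C(NC(=O)Nc2c(C(C)C)cccc2C(C)C)N1`, compound 2 `CCCCCCN1NN=C(NC(=O)Nc2c(C(C)C)cccc2C(C)C)N1` and compound 3 `CCCCCCCCCCCCN1NN=C(NC(=O)Nc2c(C(C)C)cccc2C(C)C)N1` share one core and differ only in the length of the saturated chain on the ring nitrogen. In an assay on microsomes from intestine for inhibition of acyl-CoA:cholesterol acyltransferase (Oryctolagus cuniculus) (on this read-out higher numbers stand for weaker inhibition and lower numbers for stronger inhibition), compound 1 gives 92 nM. In this assay compound 2 gives 73 nM. In this assay compound 3 gives 14 nM, the lowest of the three numbers, with compound 2 nearest and compound 1 furthest, both beyond the scatter.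

The measured steps: a 1.3-fold lower number from compound 1 to compound 2 (0.10 log units; within the scatter); a 5.2-fold lower number from compound 2 to compound 3 (0.72 log units; beyond the scatter); a 6.6-fold lower number from compound 1 to compound 3 (0.82 log units; beyond the scatter). Lengthening the chain has so far lowered the number, but only the long extensions did so beyond the scatter, while the short one stayed within it.

Compound 4 `CCCCCCCCCCCCCN1NN=C(NC(=O)Nc2c(C(C)C)cccc2C(C)C)N1` carries the smallest possible extension of the same kind, (methyl in place of hydrogen on a saturated chain carbon, ten or more bonds along the chain from an amine nitrogen in a ring). All three measured steps bear on it, since each is a chain extension at the same end; per added carbon they amount to far less than the scatter. One added carbon is therefore expected to give at most a small shift toward a lower number in this assay, likely within the scatter, as a 1.3-fold lower number from compound 3 to compound 4 (0.10 log units; within the scatter). Compound 4 is estimated at 11 nM in this assay, with a range from 5 nM to 25 nM.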

Compound 4, half-maximal inhibitory concentration: 9 nM
For compound 4 the middle estimate is 1.2-fold (0.09 log units) above the measured one; the range from low to high includes it.
By their numbers in this assay, from the lowest: compounds 4 and 3 (each within the scatter of the next); then compounds 2 and 1 (each within the scatter of the next).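

At the far end of the chain, methyl in place of hydrogen gives a 1.6-fold lower number from compound 3 to compound 4 (0.19 log units; within the scatter) in this assay, so compound 3 and compound 4 cannot be told apart at this position. Among these compounds, measured from the shorter chains, compound 4 extends the trend: heptyl in place of hydrogen gives an 8.1-fold lower number from compound 2 to compound 4 (0.91 log units; beyond the scatter), and nonyl in place of hydrogen gives a 10-fold lower number from compound 1 to compound 4 (1.01 log units; beyond the scatter), the first large step. The four compounds now fall into two pairs, compound 1 with compound 2 and compound 3 with compound 4, with every step between the pairs beyond the scatter and neither step within a pair beyond it.

No independent measurement is available to explain this dependence on chain length. On these data alone, it remains open whether a longer chain would keep, lose or further lower the number, where between the hexyl chain of compound 2 and the chain of compound 3 the drop occurs, and whether a chain ending in a carboxylic acid or an amine would fit the same pattern.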